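Swapping an Amine Chain for a Piperazine Ring

The compounds below may be only part of what the source reports. "The series", "measured", "known", "first", "only" and "open" are said of these compounds alone.

Compound 1 `COc1ccc(C(=O)Nc2ccc(-c3ccncc3)cc2)cc1CCCN(C)C` gives, in an assay on striatum for binding affinity to 5-hydroxytryptamine receptor 1D (Cavia porcellus), in the presence of a further agent that is not named here (a higher number here means a weaker inhibitor, a lower number a stronger inhibitor), a value of 10 nM, the highest number among the three compounds measured. Compound 2 `COc1ccc(C(=O)Nc2ccc(-c3ccc(C=O)cc3C)cc2)cc1CCCN(C)C` gives 6.31 nM, and compound 3 `COc1ccc(NC(=O)c2ccc(-c3ccncc3)cc2)cc1N1CCN(C)CC1` gives 5.01 nM; both of these lie within the scatter of compound 1. Compound 4 `COc1ccc(C(=O)Nc2ccc(-c3ccncc3)cc2)cc1N1CCN(C)CC1` differs from compound 1 by 4-methylpiperazin-1-yl in place of 3-(dimethylamino)propyl on an aromatic carbon. Among the measured compounds shown here, no measured one-place step covers this change: the only such step, a 1.6-fold lower number from compound 1 to compound 2 (0.20 log units; within the scatter), alters a different position and stays within the scatter. Compound 3 also carries 4-methylpiperazin-1-yl but differs from compound 1 elsewhere as well; compound 3 shows 5.01 nM, while compound 1 shows 10 nM, a gap within the scatter. The expected outcome is a 1.6-fold lower number from compound 1 to compound 4 (0.20 log units; within the scatter), no change beyond the scatter. Compound 4 is therefore estimated at 6.3 nM, between 2 nM and 20 nM.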

Compound 4, inhibition constant: 3.16 nM
Estimate against measurement, compound 4: 2.0-fold (0.30 log units) above, and the stated range covers the measured number.
By their numbers in this assay, from the lowest: compounds 4, 3, 2 and 1 (each within the scatter of the next, the first and the last beyond it).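

In this assay, at the aromatic carbon ortho to a methoxy group, 4-methylpiperazin-1-yl in place of 3-(dimethylamino)propyl gives a 3.2-fold lower number from compound 1 to compound 4 (0.50 log units; beyond the scatter), the only step shown that passes beyond the scatter. The open amine chain at this position can therefore be exchanged for a ring without loss of binding affinity. No evidence here bears on why the number falls.

On these data alone, whether the shift belongs to the ring or to its second nitrogen remains open. So does how a piperidine, a morpholine or an unmethylated piperazine would fare at this position.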